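Amide nitrogen substituent and cytotoxicity in the pyrazole series

This account rests on a few compounds, and the source may have more. Where it says the series, first, only, none or still open, it means among the compounds named here.

Three amides sharing one core have been run in a toxicity assay on HepG2 2.2.15 cells (Homo sapiens) for cytotoxicity, read by CCK-8 assay, with a stated time of 8 days; a higher number here means that more compound is tolerated, a lower number that less compound is tolerated. Compound 1 `CC(C)Cc1nn(-c2cccc(F)c2)cc1C(=O)NCc1ccccc1` gives 85900 nM. Compound 2 `CC(C)Cc1nn(-c2cccc(F)c2)cc1C(=O)NCc1ccc(F)cc1` reaches only the limit of > 100000 nM. Compound 3 `CC(C)Cc1nn(-c2cccc(F)c2)cc1C(=O)Nc1ccc(F)cc1` gives 36200 nM, the lowest of the two numbers; the step of a 2.4-fold lower number from compound 1 to compound 3 (0.38 log units; beyond the scatter) and the step of an at least 2.7-fold lower number from compound 2 to compound 3 (0.44 log units; beyond the scatter) both lie beyond the scatter. Compound 4 `CC(C)Cc1nn(-c2cccc(F)c2)cc1C(=O)NCc1ccncc1` is not yet measured; it differs from compound 3 by (pyridin-4-yl)methyl in place of 4-fluorophenyl on an amide-type nitrogen. This change reverses the direction of those two steps, swapping an aryl amide back to a methylene-linked aryl amide, so a modest rise in this assay is expected for compound 4, of about a 2.5-fold higher number from compound 3 to compound 4 (0.40 log units; beyond the scatter). Compound 4 is therefore estimated at 90000 nM, within 40000 nM to 200000 nM.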

Compound 4, half-maximal cytotoxic concentration: > 100000 nM
Compound 4 ended at the assay's limit (the forecaster's own chance of this, stated with the estimate: 40%); at least 1.1-fold (0.04 log units) between middle value and limit.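

In this assay, (pyridin-4-yl)methyl on the amide-type nitrogen extends the separation of the methylene-linked amides from the 4-fluorophenyl amide to a ring holding a hetero atom, with an at least 2.7-fold higher number from compound 3 to compound 4 (0.44 log units; beyond the scatter). Against the benzyl amide there is only an at least 1.1-fold higher number from compound 1 to compound 4 (0.06 log units; that floor lies within the scatter), and the step from compound 2 to compound 4 cannot be read. Compound 4 gives a limit, not a number, and the upper end of the range now caps this series: the limit of > 100000 nM in this assay, at which 2 of the 4 values shown sit.

Compound 3 remains the only directly nitrogen-bound aryl amide, so that lower number rests on one compound. On these data alone, how a longer chain or a (piperidin-4-yl)methyl group on the amide-type nitrogen would read remains open.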